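Thiomethyl chain tail on the pyrazolopyrimidine series

A few compounds are considered here, and "the series" means these few. Any claim that something is new, unique, unknown or untested is made for them only; others in the source may bear on it.

Measured so far in a functional assay on HT cells (Homo sapiens) for antiproliferative activity, read by fluorescence, with a stated time of 72 h; a lower number here means a stronger inhibitor of growth, a higher number a weaker inhibitor of growth:
compound 1 `CC(C)c1n[nH]c2c(NCc3ccc(-c4ccccn4)cc3)nc(SCC(O)CO)nc12` gives 21 nM;
compound 2 `CC(C)c1n[nH]c2c(NCc3ccc(-c4ccccn4)cc3)nc(SCC(N)CN)nc12` gives 480 nM;
compound 3 `CC(=O)NCCSc1nc(NCc2ccc(-c3ccccn3)cc2)c2[nH]nc(C(C)C)c2n1` gives 71 nM.

Compound 3 stands second highest of the three numbers in this assay, with a gap of a 3.4-fold higher number from compound 1 to compound 3 (0.53 log units; beyond the scatter) on one side and a 6.8-fold lower number from compound 2 to compound 3 (0.83 log units; beyond the scatter) on the other. Compound 4 `CSCCSc1nc(NCc2ccc(-c3ccccn3)cc2)c2[nH]nc(C(C)C)c2n1` keeps the shared core and the sulfur-linked chain but changes its end: methylsulfanyl in place of acetamido on a saturated chain carbon, two bonds along the chain from a sulfur. Within the data shown here, no measured step swaps this exact pair of groups; the two steps above show that the chain tail moves the number over a modest to large span. The loss of the donor of compound 3 suggests a small shift, and the estimate for compound 4 is 110 nM (range 35 nM to 350 nM), expected as a 1.5-fold higher number from compound 3 to compound 4 (0.19 log units; within the scatter).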

Compound 4, concentration for 50% growth inhibition: 975 nM
Estimate against measurement, compound 4: 8.9-fold (0.95 log units) below; measured number outside the range, above it.
By their numbers in this assay, from the lowest: compound 1; then compound 3; then compound 2; then compound 4.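

In this assay, replacing acetamido with methylsulfanyl at this chain end is a large loss (a 14-fold higher number from compound 3 to compound 4 (1.14 log units; beyond the scatter)), so this position responds to more than the earlier tail swaps showed. Compound 4 has the highest number of the four, even against the diamine tail (a 2.0-fold higher number from compound 2 to compound 4 (0.31 log units; beyond the scatter)) and more so against the diol tail (a 46-fold higher number from compound 1 to compound 4 (1.67 log units; beyond the scatter)). The change removes the hydrogen-bond donor of acetamido, but no measurement here explains the loss.

Still open, as far as these compounds go, is whether a 2-hydroxyethyl or 2-aminoethyl tail would recover the number of compound 3. Also open, from the compounds shown here alone, is how a carboxylic acid or a longer chain at this end would behave.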